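Three Amides at a Limit, a Fourth Awaiting Measurement

The source may hold more compounds than are shown below. What is called first, only, known or untested is meant among the compounds shown, and "the series" means these compounds.

Compound 1 `CS(=O)(=O)c1ccc(C(=O)Nc2ccc(Cl)c(-c3nnc4c(Cl)cccn34)c2)cc1` — in a functional assay on MDA-MB-231 cells (Homo sapiens) for antiproliferative activity, read by MTT assay, with stated times of 72 h and 4 h (a higher number here means a weaker inhibitor, a lower number a stronger inhibitor), compound 1 gives > 100000 nM, a limit of the assay.
Compound 2 `O=C(Nc1ccc(Cl)c(-c2nnc3c(Cl)cccn23)c1)c1ccc(Cl)cc1Cl` — in this assay compound 2 gives > 100000 nM, again a limit.
Compound 3 `O=C(Nc1ccc(Cl)c(-c2nnc3c(Cl)cccn23)c1)c1ccon1` — in this assay compound 3 gives > 100000 nM, also a limit.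

Compound 3 therefore stands at the same limit as the other two measured compounds; this is the limit of > 100000 nM in this assay, at which 3 of the 3 values shown sit, and no real number is known for any of them. The steps between the measured compounds are all unreadable: a step that the two limits leave unreadable from compound 1 to compound 2, a step that the two limits leave unreadable from compound 1 to compound 3 and a step that the two limits leave unreadable from compound 2 to compound 3. Compound 4 `O=C(Nc1ccc(Cl)c(-c2nnc3c(Cl)cccn23)c1)c1c(F)cccc1Cl` differs from compound 3 only at the amide carbonyl, where (2-chloro-6-fluorophenyl in place of 1,2-oxazol-3-yl on a carbonyl carbon). The measured steps that bear on this change are those that swap one amide acyl group for another, and none of them could be sized, because every value sits at the limit (the limit of > 100000 nM in this assay, at which 3 of the 3 values shown sit). Compound 4 is therefore expected to behave like the three before it, most probably returning only a limit again, so that the step from compound 3 to compound 4 is estimated at a step that the limit leaves unreadable from compound 3 to compound 4. For compound 4 the estimate in this assay is 150000 nM, with a range from 30000 nM to 600000 nM.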

Compound 4, half-maximal inhibitory concentration: > 100000 nM
Compound 4: only a limit was reported; the forecaster's own chance of this, stated with the estimate: 80%; the middle value lies beyond the limit too.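

In this assay compound 4 gives > 100000 nM, which is a limit of the assay and not a number. No step linking compound 4 to compound 1, compound 2 or compound 3 can be read, as all four sit at one limit: the limit of > 100000 nM in this assay, at which 4 of the 4 values shown sit.

The compounds shown leave open whether any acyl group on the shared core gives a measurable value in this assay.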